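Replacing Nitro with Methoxy in an Antiproliferative Series

The compounds below may be only part of what the source reports. "The series", "measured", "known", "first", "only" and "open" are said of these compounds alone.

In a functional assay on HeLa cells (Homo sapiens) for antiproliferative activity, read by MTT assay, with a stated time of 48 h (on this read-out lower numbers stand for stronger inhibition and higher numbers for weaker inhibition), compound 1 (`O=[N+]([O-])c1cccc(-c2nn(-c3ccccc3)cc2C(Nc2nc3ccccc3s2)c2c(O)ccc3ccccc23)c1`) gives 8220 nM, the middle of three numbers. Compound 2 (`Cc1ccc2nc(NC(c3cn(-c4ccccc4)nc3-c3cccc([N+](=O)[O-])c3)c3c(O)ccc4ccccc34)sc2c1`) gives 7360 nM and compound 3 (`Cc1cc2nc(NC(c3cn(-c4ccccc4)nc3-c3ccc([N+](=O)[O-])cc3)c3c(O)ccc4ccccc34)sc2cc1C`) gives 14700 nM, and both lie within the scatter of compound 1. The next compound, compound 4 (`COc1cccc(-c2nn(-c3ccccc3)cc2C(Nc2nc3ccccc3s2)c2c(O)ccc3ccccc23)c1`), has not yet been measured. It differs from compound 1 by methoxy in place of nitro on an aromatic carbon, so 3-nitrophenyl becomes 3-methoxyphenyl.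

Among the compounds with values here, the only measured step between compounds differing in one place is a 1.1-fold lower number from compound 1 to compound 2 (0.05 log units; within the scatter), a methyl in place of hydrogen on an aromatic carbon, and it lies within the scatter. That step leaves the nitro untouched, so it bears only loosely on this change. Within the data shown here, compound 3 differs from compound 1 in more than one place and offers no clean step. Among the measured compounds shown here, with no measured step to suggest a direction, no shift beyond the scatter is expected in this assay, though the uncertainty is wide. The expected step is a 1.0-fold lower number from compound 1 to compound 4 (0.01 log units; within the scatter). For compound 4 the estimated value is 8000 nM, with an expected range from 3000 nM to 22000 nM.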

Compound 4, half-maximal inhibitory concentration: 14900 nM
Compound 4: middle estimate off by 1.9-fold (0.27 log units), on the low side, within the range that was stated.
By their numbers in this assay, from the lowest: compounds 2, 1, 3 and 4 (each within the scatter of the next, the first and the last beyond it).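

In this assay, the exchange of 3-nitrophenyl for 3-methoxyphenyl gives a 1.8-fold higher number from compound 1 to compound 4 (0.26 log units; within the scatter), and this first change to the nitro does not separate compound 4 from compound 1 beyond the scatter. Within the data shown here, all the earlier compounds carried the nitro, so they could not show whether activity in this assay depends on it; this pair shows that, on this aromatic carbon, methoxy can stand in its place with no shift that can be told from the scatter. No measurement in hand bears on the reason for this outcome. The compounds shown leave open whether an amine, a carboxylic acid or a longer chain such as an ethoxy group would be tolerated on the same carbon. They also leave open whether the methoxy would give the same result alongside the methyl of compound 2.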